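Compound 2 to compound 4: hydroxy in place of hydrogen

The source may hold more compounds than are shown below. What is called first, only, known or untested is meant among the compounds shown, and "the series" means these compounds.

Measured so far in a functional assay on MC-38 cells (Mus musculus) for antiproliferative activity, read by colorimetric assay and MTT assay (a higher number here means a weaker inhibitor, a lower number a stronger inhibitor), for this series
- compound 1 `COc1ccc(S(=O)(=O)Nc2cccc3cc(O)[nH]c23)cc1` gives 0.22 ug/mL
- compound 2 `O=[N+]([O-])c1ccc(S(=O)(=O)Nc2cccc3cc[nH]c23)cc1` gives 7.2 ug/mL
- compound 3 `O=[N+]([O-])c1ccc(S(=O)(=O)Nc2cccc3c(Cl)c[nH]c23)cc1` gives 0.34 ug/mL

Not yet measured: compound 4 `O=[N+]([O-])c1ccc(S(=O)(=O)Nc2cccc3cc(O)[nH]c23)cc1`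

Compound 2 holds the highest number of the three, so there is room for a move downward. The change to compound 4 is hydroxy in place of hydrogen on an aromatic carbon and amounts to hydroxy in place of hydrogen on an aromatic carbon, next to the ring nitrogen. For the measured compounds named here, the one measured step from compound 2 is a 21-fold lower number from compound 2 to compound 3 (1.33 log units; beyond the scatter) with chloro in place of hydrogen, which is large but involves a different group. Going by the values given here, compound 1 gives 0.22 ug/mL with the same hydroxy, but it differs from compound 4 elsewhere, so no measured step isolates hydroxy. Both of these point to a large step toward a lower number, with wide uncertainty. The expected change is a 9.0-fold lower number from compound 2 to compound 4 (0.95 log units; beyond the scatter) and would lie beyond the scatter. For compound 4 the estimate is 0.8 ug/mL with an expected range from 0.2 ug/mL to 3.5 ug/mL as the working bounds.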

Compound 4, half-maximal inhibitory concentration: 62 ug/mL
The estimate for compound 4 lay 78-fold (1.89 log units) below the measured number; measured number above the stated range.
By their numbers in this assay, from the lowest: compounds 1 and 3 (each within the scatter of the next); then compound 2; then compound 4.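

In this assay, hydroxy in place of hydrogen on an aromatic carbon next to the ring nitrogen gives an 8.6-fold higher number from compound 2 to compound 4 (0.94 log units; beyond the scatter), so with nitro held constant this change moves the number upward, making the inhibitor weaker. With hydroxy held constant, nitro in place of methoxy gives a 280-fold higher number from compound 1 to compound 4 (2.45 log units; beyond the scatter), so the presence of hydroxy at this position does not by itself set the number, and the low value of compound 1 cannot be credited to hydroxy alone. Nothing available explains either step.

As far as these compounds go, whether hydroxy also raises the number when methoxy stands in place of nitro remains open. From the compounds shown here alone, it is also open how this carbon responds to a different group, such as an amine or a methyl group.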